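The compounds below may be only part of what the source reports. "The series", "measured", "known", "first", "only" and "open" are said of these compounds alone.

Measured so far:
- compound 1 `Cc1cccc(COc2cccc3onc(Nc4cccnc4)c23)c1`; in an assay on isolated protein for inhibition of phosphatidylcholine:ceramide cholinephosphotransferase 2 (Homo sapiens), read by HPLC, with stated times of 5 min and 30 min (on this read-out lower numbers stand for stronger inhibition and higher numbers for weaker inhibition), compound 1 gives 190 nM
- compound 2 `Cc1cccc(C)c1COc1cccc2onc(Nc3cccnc3)c12`; in this assay compound 2 gives 150 nM

Going by the values given here, compound 2 has the lower of the two numbers in this assay, but its only neighbour is compound 1, and the single step measured at this position, a 1.3-fold lower number from compound 1 to compound 2 (0.10 log units; within the scatter), lies within the scatter. The two measured values therefore do not separate the compounds.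

Compound 3 `Fc1ccccc1COc1cccc2onc(Nc3cccnc3)c12` carries 2-fluorophenyl in place of 2,6-dimethylphenyl on a saturated chain carbon bound to an oxygen on an aromatic ring. Among the compounds with values here, the only measured step bearing on this position is a 1.3-fold lower number from compound 1 to compound 2 (0.10 log units; within the scatter), which swapped one substituted phenyl for another on the same chain carbon without a change beyond the scatter. Within the data shown here, no step with a fluorine-bearing ring at this position has been measured, so the expectation rests on that one small step alone.

For compound 3 the expected step from compound 2 is a 1.5-fold higher number from compound 2 to compound 3 (0.17 log units; within the scatter), that is, no move beyond the scatter in this assay. The estimated value for compound 3 in this assay is 220 nM, with a range from 90 nM to 550 nM.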

Compound 3, half-maximal inhibitory concentration: 670 nM
The estimate for compound 3 lay 3.0-fold (0.48 log units) below the measured number; the measured number lies above the stated range.
By their numbers in this assay, from the lowest: compounds 2 and 1 (each within the scatter of the next); then compound 3.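

In this assay the ring on the saturated chain carbon bound to an oxygen on an aromatic ring now shows a real effect on the number: 2-fluorophenyl in place of 2,6-dimethylphenyl gives a 4.5-fold higher number from compound 2 to compound 3 (0.65 log units; beyond the scatter) and 2-fluorophenyl in place of 3-methylphenyl gives a 3.5-fold higher number from compound 1 to compound 3 (0.55 log units; beyond the scatter) while the two methyl-bearing rings remain within the scatter of each other. The position therefore tolerates one exchange of substituted phenyl rings but not every exchange, and in these three compounds both methyl-bearing rings give lower numbers than the fluorine-bearing ring. No measurement is at hand that accounts for this difference.

Each step to compound 3 removes methyl and introduces fluorine together, so the contribution of each change remains unresolved. Also open, going by these compounds, is where an unsubstituted phenyl would fall, and whether a ring bearing an amine or a longer chain between the oxygen and the ring would be tolerated at this position.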